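Moving the chlorine on the urea phenyl ring

The source may hold more compounds than are shown below. What is called first, only, known or untested is meant among the compounds shown, and "the series" means these compounds.

Three ureas built on one shared core have been tested in a functional assay on T98G cells (Homo sapiens) for inhibition, read by MTT assay, with a stated time of 72 h; on this read-out higher numbers stand for weaker inhibition and lower numbers for stronger inhibition. Compound 1 `CC1(C)CC(NC(=O)Nc2cccc(Cl)c2)c2cc(Br)ccc2O1` gives 67000 nM. Compound 2 `CC1(C)CC(NC(=O)Nc2ccc(Cl)cc2)c2cc(Cl)ccc2O1` gives 33000 nM, while compound 3 `CC1(C)CC(NC(=O)Nc2ccc(Cl)cc2)c2cc(Br)ccc2O1` gives 27000 nM. The cores of compound 2 and compound 3 differ by chloro in place of bromo on an aromatic carbon, and the step of a 1.2-fold lower number from compound 2 to compound 3 (0.09 log units; within the scatter) lies within the scatter. Between compound 3 and compound 1 the change is 3-chlorophenyl in place of 4-chlorophenyl on an amide-type nitrogen, which produced a 2.5-fold higher number from compound 3 to compound 1 (0.39 log units; beyond the scatter). Compound 4 `CC1(C)CC(NC(=O)Nc2cccc(Cl)c2)c2cc(Cl)ccc2O1` has not yet been measured; it arises from compound 2 through (3-chlorophenyl in place of 4-chlorophenyl on an amide-type nitrogen), the same change at the same place. Because compound 2 gives 33000 nM and the earlier step was a 2.5-fold higher number from compound 3 to compound 1 (0.39 log units; beyond the scatter), compound 4 is expected to show a step of about a 2.4-fold higher number from compound 2 to compound 4 (0.38 log units; beyond the scatter). In this assay compound 4 is therefore estimated at 80000 nM, with a likely range from 35000 nM to 180000 nM.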

Compound 4, half-maximal inhibitory concentration: 25000 nM
Estimate against measurement, compound 4: 3.2-fold (0.51 log units) above; the measured number lies below the stated range.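

In this assay, 3-chlorophenyl in place of 4-chlorophenyl on the chloro core gave a 1.3-fold lower number from compound 2 to compound 4 (0.12 log units; within the scatter), so the step seen on the bromo core did not carry over: the same change on two cores in this assay, a 2.5-fold higher number (0.39 log units; beyond the scatter) from compound 3 to compound 1 and a 1.3-fold lower number (0.12 log units; within the scatter) from compound 2 to compound 4, 3.3-fold (0.52 log units) apart, beyond the scatter of two such steps. Read the other way, chloro in place of bromo gave a 2.7-fold lower number from compound 1 to compound 4 (0.43 log units; beyond the scatter), so the effect of that swap also depended on the core: the same change on two cores in this assay, a 1.2-fold lower number (0.09 log units; within the scatter) from compound 2 to compound 3 and a 2.7-fold higher number (0.43 log units; beyond the scatter) from compound 4 to compound 1, 3.3-fold (0.52 log units) apart, beyond the scatter of two such steps. In these four compounds the two changes therefore do not act independently, but the data show neither why this is so nor which step is the exception.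

The compounds shown leave open how an unsubstituted phenyl, a 2-chlorophenyl or a methoxyphenyl on the same nitrogen would behave. They also leave open whether a fluoro or methyl on the core would follow the chloro or the bromo pattern.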